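This account rests on a few compounds, and the source may have more. Where it says the series, first, only, none or still open, it means among the compounds named here.

Measured in an ADME assay on the whole organism (Rattus norvegicus) for pharmacokinetics, at a dose of 0.5 mg/kg by the intravenous route; a lower number here means slower removal, a higher number faster removal of the compound:
- compound 1 `CNC(=O)N(c1ccc(S(=O)(=O)Nc2ccon2)cn1)c1cc(F)c(-c2ccc(F)c(OC(F)(F)F)c2)cc1OC`: 7070 mL/min/kg
- compound 2 `CNC(=O)N(c1ccc(S(=O)(=O)Nc2ncccn2)cn1)c1cc(F)c(-c2cccc(C(F)(F)F)c2)cc1OC`: 267 mL/min/kg

Compound 1 stands highest of these two numbers, and the gap to compound 2 lies beyond the scatter. Still unmeasured is compound 3 `CNC(=O)N(c1ccc(S(=O)(=O)Nc2cccnn2)cn1)c1cc(F)c(-c2ccc(F)c(OC(F)(F)F)c2)cc1OC`, which differs from compound 1 in one place: pyridazin-3-yl in place of 1,2-oxazol-3-yl on a sulfonamide nitrogen. Within the data shown here, no measured pair isolates this change, so any expectation rests on thin evidence. Among the measured compounds shown here, compound 2 gives 267 mL/min/kg, the only reading available well under that of compound 1, so a downward move is the working assumption. The expected change is a 4.7-fold lower number from compound 1 to compound 3 (0.67 log units; beyond the scatter), a decrease estimated to lie beyond the scatter, though with wide uncertainty. For compound 3 the estimated clearance is 1500 mL/min/kg, with an expected range of 300 mL/min/kg to 7000 mL/min/kg.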

Compound 3, clearance: 1150 mL/min/kg
Compound 3: the middle estimate sits 1.3-fold (0.12 log units) above what was measured; the range from low to high includes it.
By their numbers in this assay, from the lowest: compound 2; then compound 3; then compound 1.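

In this assay, the group on the sulfonamide nitrogen can shift clearance by itself: pyridazin-3-yl in place of 1,2-oxazol-3-yl, with the rest of compound 1 unchanged, gives a 6.1-fold lower number from compound 1 to compound 3 (0.79 log units; beyond the scatter). Among these compounds, the gap between compound 1 and compound 2 could not show this, as those two differ in more than one place, so this pair is the only direct reading of the position. Nothing measured on these compounds bears on the reason for the step.

A single pair on a single background leaves open whether the step would hold on the rest of compound 2. Also open, on these data alone, is how a plain phenyl or a methyl on the same sulfonamide nitrogen would read in this assay.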